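Swapping carbamoyl for cyano: what plasma half-life to expect

The compounds below may be only part of what the source reports. "The series", "measured", "known", "first", "only" and "open" are said of these compounds alone.

Measured so far:
compound 1 `CC(=O)N[C@@H](C)C(=O)N(C)/N=N/c1ccc(C(N)=O)cc1`: 7.6 h
compound 2 `CC(=O)N[C@H](C(=O)N(C)/N=N/c1ccc(C#N)cc1)C(C)C`: 5.7 h

Of the compounds shown here, two have been measured in an ADME assay on a cell-free system (plasma, Homo sapiens) for metabolic stability, read by HPLC; a lower number here means that the compound disappears faster, a higher number that the compound lasts longer. Compound 1 `CC(=O)N[C@@H](C)C(=O)N(C)/N=N/c1ccc(C(N)=O)cc1` gives 7.6 h and holds the highest of the two numbers. Compound 2 `CC(=O)N[C@H](C(=O)N(C)/N=N/c1ccc(C#N)cc1)C(C)C` gives 5.7 h, and the two values lie within the scatter of each other, so nothing separates them. Compound 3 `CC(=O)N[C@@H](C)C(=O)N(C)/N=N/c1ccc(C#N)cc1` has not yet been measured. It differs from compound 1 in one place: cyano in place of carbamoyl on an aromatic carbon. Among the measured compounds shown here, no measured pair shows this change on its own, so its size is not known from the data. Compound 2 also carries the cyano group, and its half-life in this assay does not differ from that of compound 1 beyond the scatter. No step beyond the scatter is therefore expected in either direction. The expected step is a 1.2-fold lower number from compound 1 to compound 3 (0.07 log units; within the scatter). Compound 3 is expected to show 6.5 h, with a range from 3.5 h to 12 h.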

Compound 3, half-life: 1 h
Estimate against measurement, compound 3: 6.5-fold (0.81 log units) above, and the stated range ends above it.
By their numbers in this assay, from the lowest: compound 3; then compounds 2 and 1 (each within the scatter of the next).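

In this assay cyano in place of carbamoyl on the aromatic carbon gives a 7.6-fold lower number from compound 1 to compound 3 (0.88 log units; beyond the scatter) and so is not a neutral change at this position when the chain carries methyl. Methyl in place of isopropyl on the saturated chain carbon gives a 5.7-fold lower number from compound 2 to compound 3 (0.76 log units; beyond the scatter) with cyano unchanged, so the group on the chain counts as well. Cyano alone therefore does not set the number, since compound 2 carries it too, and among these compounds only its pairing with methyl in compound 3 gives the low value.

Nothing measured here explains these steps. Also open, as far as these compounds go, is whether another group on the aromatic carbon, such as a carboxylic acid or an amine, would follow carbamoyl or cyano.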